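Bromo for Chloro on the Isatin Core: Two Related Series

A few compounds are considered here, and "the series" means these few. Any claim that something is new, unique, unknown or untested is made for them only; others in the source may bear on it.

Measured compounds:
compound 1, `O=C1C(=O)N(CCCNc2ccnc3cc(Cl)ccc23)c2cccc(Cl)c21`: 84800 nM
compound 2, `O=C1C(=O)N(CCCNc2ccnc3cc(Cl)ccc23)c2cccc(Br)c21`: 20800 nM
compound 3, `O=C1C(=O)N(CCCNc2ccnc3cc(C(F)(F)F)ccc23)c2cc(Cl)ccc21`: 25200 nM

Of the compounds shown here, three have been tested in an ADME assay on MCF-10A cells (Homo sapiens) for antiproliferative activity, read by sulforhodamine B assay, with a stated time of 48 h; a lower number here means a stronger inhibitor of growth, a higher number a weaker inhibitor of growth. Compound 1 gives 84800 nM in this assay. Compound 2 differs from compound 1 by a single exchange, (bromo in place of chloro on an aromatic carbon), and the step is a 4.1-fold lower number from compound 1 to compound 2 (0.61 log units; beyond the scatter). Compound 3 belongs to a second core; the difference between the core of compound 3 and the core of compound 1 is not broken down here. Compound 3 gives 25200 nM in this assay, a number that sits within the scatter of compound 2 and beyond it from compound 1.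

Compound 4, `O=C1C(=O)N(CCCNc2ccnc3cc(C(F)(F)F)ccc23)c2cc(Br)ccc21`, has not been measured. It stands to compound 3 as compound 2 stands to compound 1, through the exchange (bromo in place of chloro on an aromatic carbon). It is the same kind of change, not the same one: in compound 1 the place is ortho to a fused ring and meta to a fused ring, whereas in compound 3 it is meta to a fused ring and para to a fused ring.

Going by the values given here, the single earlier example of this change, the step from compound 1 to compound 2, was a lower number, so a lower number is expected for compound 4 as well, though with only one precedent on a different place the step is estimated more cautiously as a 2.1-fold lower number from compound 3 to compound 4 (0.32 log units; beyond the scatter). Compound 4 is therefore expected to give about 12000 nM in this assay, with a likely range from 5000 nM to 30000 nM.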

Compound 4, concentration for 50% growth inhibition: 14600 nM
Compound 4: middle estimate off by 1.2-fold (0.09 log units), on the low side, and the stated range covers the measured number.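

On the second core, bromo in place of chloro on an aromatic carbon, at the place meta to a fused ring and para to a fused ring, gives a 1.7-fold lower number from compound 3 to compound 4 (0.24 log units; within the scatter) in this assay, so on this core the exchange does not separate compound 4 from compound 3. Set side by side, the steps on the two cores cannot be told apart in size, and the change is thus compatible with a single step shared by both cores: the same change on two cores in this assay, a 4.1-fold lower number (0.61 log units; beyond the scatter) from compound 1 to compound 2 and a 1.7-fold lower number (0.24 log units; within the scatter) from compound 3 to compound 4, 2.4-fold (0.37 log units) apart, within the scatter of two such steps This does not show that the change carries over as a fixed step, since there are only two examples, only the first lies beyond the scatter, and the two cores also differ in the place of the exchange, so any effect of the core cannot be separated from one of the place.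

The compounds shown leave open how bromo and chloro compare when the place of the exchange is held the same on both cores, and whether a step of similar size would appear with fluoro, iodo or a nitrile on that aromatic carbon. They also leave open whether either step would hold with a longer chain in the linker or with an amide in its place.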